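Bromo for Methoxy: What to Expect of Compound 4

This account rests on a few compounds, and the source may have more. Where it says the series, first, only, none or still open, it means among the compounds named here.

Compound 1 `COc1ccccc1/C=C/C(=O)c1ccc(OCC(=O)N[C@H]2CCOC2=O)cc1` was run in a functional assay on MGC-803 cells (Homo sapiens) for antiproliferative activity, read by MTT assay, with a stated time of 72 h (a lower number here means a stronger inhibitor, a higher number a weaker inhibitor), where compound 1 gives 39400 nM. In this assay compound 2 `O=C1OCC[C@@H]1NC(=S)SCCOc1ccccc1[N+](=O)[O-]` gives 47000 nM; this number and that of compound 1 sit within the usual scatter of each other, so no order between them can be read. In this assay compound 3 `CCCCCCCCCCSC(=S)N[C@H]1CCOC1=O` gave only a limit, > 64000 nM, and no number (the limit of > 64000 nM in this assay, at which 1 of the 3 values shown sits). Of the two actual numbers, compound 1 stands lowest, with compound 2 nearest.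

Compound 4 `O=C(COc1ccc(C(=O)/C=C/c2ccccc2Br)cc1)N[C@H]1CCOC1=O` has not yet been measured. It differs from compound 1 in one place: bromo in place of methoxy on an aromatic carbon. No measured pair among these three compounds isolates a change of this kind, so the results give no direction for it. The step from compound 1 to compound 4 is therefore expected to stay within the scatter, a 1.1-fold lower number from compound 1 to compound 4 (0.05 log units; within the scatter). Compound 4 is estimated at 35000 nM, with an expected range from 12000 nM to 100000 nM.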

Compound 4, half-maximal inhibitory concentration: 12200 nM
For compound 4 the middle estimate is 2.9-fold (0.46 log units) above the measured one, and the stated range covers the measured number.
By their numbers in this assay, from the lowest: compound 4; then compounds 1 and 2 (each within the scatter of the next). At a limit, above all of these: compound 3.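

In this assay, for the compounds shown here, the pair of compound 1 and compound 4 is the first to isolate a single change, and it gives that change a direction: bromo in place of methoxy brings a 3.2-fold lower number from compound 1 to compound 4 (0.51 log units; beyond the scatter). So this aromatic carbon, ortho to a large group, is a place where swapping one small group for another moves the number by more than the usual scatter, although the step is not a large one. Nothing measured here bears on why the number falls with this change.

From the compounds shown here alone, with only these two groups compared at this place, it remains open whether chloro, methyl, an amine or a carboxylic acid would follow bromo or stay closer to methoxy. Going by these compounds, it also remains open whether bromo would bring a similar step on another carbon of the same ring.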